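Shrinking the Ring on the Sulfonamide Side Chain

The source may report more compounds than this note shows. Statements on the series, on what has been measured and on what is new or still open speak of the compounds shown alone.

Three sulfonamides share one core and differ only in the ring carried on the saturated chain carbon bound to the sulfonamide nitrogen. In a physicochemical assay for lipophilicity, read by HPLC, measured as octanol-water partition, at pH 7.4 (on this read-out higher numbers stand for higher lipophilicity and lower numbers for lower lipophilicity), compound 1 `CC1(C)C[C@H](CN([C@H](CCC(F)(F)F)C(N)=O)S(=O)(=O)c2ccc(Cl)cc2)O1` gives 3.8, compound 2 `NC(=O)[C@@H](CCC(F)(F)F)N(C[C@H]1CCCCO1)S(=O)(=O)c1ccc(Cl)cc1` gives 4.3 and compound 3 `NC(=O)[C@@H](CCC(F)(F)F)N(C[C@H]1CCOC1)S(=O)(=O)c1ccc(Cl)cc1` gives 2.8. Compound 2 stands highest of the three: the nearest is a number 0.50 log units higher from compound 1 to compound 2 (beyond the scatter), the furthest a number 1.50 log units lower from compound 2 to compound 3 (beyond the scatter).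

Compound 4 `NC(=O)[C@@H](CCC(F)(F)F)N(C[C@@H]1CCCO1)S(=O)(=O)c1ccc(Cl)cc1` has not yet been measured in this assay. Its difference from compound 2 is oxolan-2-yl in place of oxan-2-yl on a saturated chain carbon bound to a sulfonamide nitrogen. Of the measured steps, the closest in kind is a number 1.50 log units lower from compound 2 to compound 3 (beyond the scatter), where the oxan-2-yl also gave way to a five-membered non-aromatic ring, though one attached through a different carbon; a number 1.00 log units lower from compound 1 to compound 3 (beyond the scatter) points the same way. The change to compound 4 is smaller, one heavy atom fewer with the attachment kept, so a modest downward step is expected, a number 0.60 log units lower from compound 2 to compound 4 (beyond the scatter). Compound 4 is therefore estimated at 3.7, with a range from 3.2 to 4.2.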

Compound 4, distribution coefficient: 3.5
Compound 4: middle estimate off by 0.20 log units, on the high side; low and high end bracket the measured number.
By their numbers in this assay, from the lowest: compound 3; then compounds 4 and 1 (each within the scatter of the next); then compound 2.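

Keeping the attachment and changing only oxan-2-yl to oxolan-2-yl at this saturated chain carbon bound to a sulfonamide nitrogen gives a number 0.80 log units lower from compound 2 to compound 4 (beyond the scatter) in this assay, so this one-atom ring change alone is enough to move the read-out. Where the attachment shifts within the five-membered ring, oxolan-2-yl in place of oxolan-3-yl gives a number 0.70 log units higher from compound 3 to compound 4 (beyond the scatter), a separation between two rings of the same size that the earlier compounds could not show. Set against 4,4-dimethyloxetan-2-yl, oxolan-2-yl gives a number 0.30 log units lower from compound 1 to compound 4 (within the scatter), so the two cannot be told apart on this read-out.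

Going by these compounds, whether an amine in the ring or a longer open chain would follow these steps remains open. Nothing at hand accounts for the size of any of these steps.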